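A few compounds are considered here, and "the series" means these few. Any claim that something is new, unique, unknown or untested is made for them only; others in the source may bear on it.

In a functional assay on HeLa cells (Homo sapiens) for inhibition (on this read-out lower numbers stand for stronger inhibition and higher numbers for weaker inhibition), compound 1 `O=C/C=C/n1ccc(=O)[nH]c1=O` gives 30000 nM, while compound 2 `O=C/C=C/n1cc(C(F)(F)F)c(=O)[nH]c1=O` gives 80000 nM, the higher of the two numbers. Compound 3 `O=C/C=C/n1cc(CO)c(=O)[nH]c1=O` has hydroxymethyl in place of trifluoromethyl on an aromatic carbon. Among the measured compounds shown here, the only measured step that bears on this change is the modest one that introduced trifluoromethyl in place of hydrogen, a 2.7-fold higher number from compound 1 to compound 2 (0.43 log units; beyond the scatter). For the measured compounds named here, a similarly modest move towards a lower number is therefore expected, although hydroxymethyl itself has no measured precedent here. The expected change is a 2.0-fold lower number from compound 2 to compound 3 (0.30 log units; within the scatter). Compound 3 is estimated at 40000 nM, with an expected range of 14000 nM to 110000 nM.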

Compound 3, half-maximal inhibitory concentration: > 100000 nM
Compound 3 was reported as a limit; the forecaster's own chance of this, stated with the estimate: 15%; middle value at least 2.5-fold (0.39 log units) from the limit.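

In this assay compound 3 is reported only as a limit: the limit of > 100000 nM in this assay, at which 1 of the 3 values shown sits. Hydroxymethyl in place of hydrogen gives an at least 3.3-fold higher number from compound 1 to compound 3 (0.52 log units; beyond the scatter) and so, like trifluoromethyl in a 2.7-fold higher number from compound 1 to compound 2 (0.43 log units; beyond the scatter), leaves this aromatic carbon with a higher number than hydrogen does. Against trifluoromethyl the reading is only an at least 1.2-fold higher number from compound 2 to compound 3 (0.09 log units; that floor lies within the scatter), so these two groups cannot be put in order.

From the compounds shown here alone, how far compound 3 lies past its limit stays open. So does whether methyl, fluorine or an amine on this carbon would give a lower number than hydrogen.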